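This account rests on a few compounds, and the source may have more. Where it says the series, first, only, none or still open, it means among the compounds named here.

Measured so far:
compound 1 `CN(Cc1ccc(OCCCNC(=N)N)cc1)c1nc2ccc(Oc3ccc(O)cc3)cc2s1`: 432000 nM
compound 2 `CN(Cc1ccc(OCCCN)cc1)c1nc2ccc(Oc3cccc(C(F)(F)F)c3)cc2s1`: 77000 nM

In an assay on SH-SY5Y cells for inhibition of Voltage-dependent N-type calcium channel subunit alpha-1B (Homo sapiens), read by FLIPR and calcium flux, with stated times of 600 s and 300 s, in the presence of a further agent that is not named here (on this read-out higher numbers stand for weaker inhibition and lower numbers for stronger inhibition), compound 2 holds the lowest of the two numbers, with compound 1 at a higher number beyond the scatter. Compound 3 `CN(Cc1ccc(OCCCN)cc1)c1nc2ccc(Oc3ccc(O)cc3)cc2s1` is not yet measured; it differs from compound 2 by 4-hydroxyphenyl in place of 3-(trifluoromethyl)phenyl on an oxygen on an aromatic ring. Going by the values given here, no measured pair isolates this change on its own. Compound 1 also carries the 4-hydroxyphenyl group, though with a different chain end, and gives 432000 nM. A modest move toward weaker inhibition is expected, a 2.6-fold higher number from compound 2 to compound 3 (0.41 log units; beyond the scatter). Compound 3 is estimated at 200000 nM, within a range of 70000 nM to 600000 nM.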

Compound 3, half-maximal inhibitory concentration: 117000 nM
Compound 3: the middle estimate sits 1.7-fold (0.23 log units) above what was measured; low and high end bracket the measured number.
By their numbers in this assay, from the lowest: compounds 2 and 3 (each within the scatter of the next); then compound 1.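

Exchanging 3-(trifluoromethyl)phenyl for 4-hydroxyphenyl on an oxygen on an aromatic ring gives a 1.5-fold higher number from compound 2 to compound 3 (0.18 log units; within the scatter), so this change does not separate the two compounds. With 4-hydroxyphenyl held fixed, the chain end does separate them: a hydrogen atom in place of the group of 3 heavy atoms on the amine nitrogen gives a 3.7-fold lower number from compound 1 to compound 3 (0.57 log units; beyond the scatter). No measured evidence bears on either step.

The compounds shown leave open whether the identity of the group or its place on the ring matters, since both differ in the first step. Other groups on that oxygen, such as 3-hydroxyphenyl or 4-(trifluoromethyl)phenyl, and other chain ends, such as a carboxylic acid or a longer chain, also remain open.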